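This account rests on a few compounds, and the source may have more. Where it says the series, first, only, none or still open, it means among the compounds named here.

Measured in a functional assay on MDA-MB-231 cells (Homo sapiens) for cytotoxicity, read by MTT assay, with a stated time of 48 h; a higher number here means a weaker inhibitor, a lower number a stronger inhibitor:
- Compound 1 `O=C(NCCCCC(c1ccc(F)cc1)c1ccc(F)cc1)Nc1ccc(I)cc1`: 11800 nM
- Compound 2 `O=C(NCCCCC(c1ccc(F)cc1)c1ccc(F)cc1)Nc1ccc([N+](=O)[O-])cc1`: 6470 nM
- Compound 3 `O=C(NCCCCC(c1ccc(F)cc1)c1ccc(F)cc1)Nc1cccc(C(F)(F)F)c1`: 3380 nM

Compound 3 sits at the low end of this short series, though not apart from compound 2. Among the compounds with values here, the data show a 1.9-fold lower number from compound 2 to compound 3 (0.28 log units; within the scatter) and, further out, a 3.5-fold lower number from compound 1 to compound 3 (0.54 log units; beyond the scatter) as the only step beyond the scatter.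

Compound 4 `O=C(NCCCCC(c1ccc(F)cc1)c1ccc(F)cc1)Nc1ccc(C(F)(F)F)cc1` carries 4-(trifluoromethyl)phenyl in place of 3-(trifluoromethyl)phenyl on an amide-type nitrogen and is still to be measured.

Within the data shown here, no measured step makes this exact change, so the guidance is indirect. The two steps to compound 3 each replace a differently substituted group, 4-iodophenyl in compound 1 and 4-nitrophenyl in compound 2, and both are small. With a 1.8-fold lower number from compound 1 to compound 2 (0.26 log units; within the scatter) also small, only a slight move toward a higher number in this assay is expected. The estimated step is a 1.3-fold higher number from compound 3 to compound 4 (0.12 log units; within the scatter) and probably no larger.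

Compound 4 is estimated at 4500 nM with 2000 nM to 10000 nM as its expected range.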

Compound 4, half-maximal inhibitory concentration: 2780 nM
Beside the measured number, compound 4's estimate is 1.6-fold (0.21 log units) above it; the measured number falls inside the stated range.
By their numbers in this assay, from the lowest: compounds 4, 3, 2 and 1 (each within the scatter of the next, the first and the last beyond it).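

In this assay, 4-(trifluoromethyl)phenyl in place of 3-(trifluoromethyl)phenyl on the amide-type nitrogen gives a 1.2-fold lower number from compound 3 to compound 4 (0.08 log units; within the scatter), so these two placements of the trifluoromethyl group cannot be told apart here. Trifluoromethyl in place of nitro gives a 2.3-fold lower number from compound 2 to compound 4 (0.37 log units; beyond the scatter) and trifluoromethyl in place of iodo gives a 4.2-fold lower number from compound 1 to compound 4 (0.63 log units; beyond the scatter), which sets compound 4 clearly apart from both, even though compound 3 stays within the scatter of compound 2. Nothing available gives a reason for any of these steps.

Still open, as far as these compounds go, is how a methoxy group, a nitrile or an amine on the aromatic ring would compare with trifluoromethyl. The compounds shown also leave open what a shorter or longer chain in the shared core would do.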